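A few compounds are considered here, and "the series" means these few. Any claim that something is new, unique, unknown or untested is made for them only; others in the source may bear on it.

In a functional assay on KB-VIN10 cells (Homo sapiens) for inhibition, with a stated time of 72 h (on this read-out higher numbers stand for weaker inhibition and lower numbers for stronger inhibition), compound 3 `COc1ccc(S(=O)(=O)N2CCc3cccc(-c4cccnc4)c32)cc1` gives 84.5 nM and compound 1 `COc1ccc(S(=O)(=O)N2CCc3cccc(-c4ccc(F)nc4)c32)cc1` gives 151 nM, a pair not separated by the data: a 1.8-fold lower number from compound 1 to compound 3 (0.25 log units; within the scatter). Compound 2 `COc1ccc(S(=O)(=O)N2CCc3cccc(-c4ccc(N(C)C)cc4)c32)cc1` stands apart at 553 nM, with a 3.7-fold higher number from compound 1 to compound 2 (0.56 log units; beyond the scatter). Compound 4 `COc1ccc(S(=O)(=O)N2CCc3cccc(-c4ccc(O)cc4)c32)cc1` has 4-hydroxyphenyl in place of pyridin-3-yl on an aromatic carbon. Among the compounds with values here, no measured compound carries 4-hydroxyphenyl. The nearest guide is a 6.5-fold lower number from compound 2 to compound 3 (0.82 log units; beyond the scatter), read in reverse, as compound 2 also holds a 4-substituted phenyl, 4-(dimethylamino)phenyl. That is a single precedent, so a higher number of smaller size is expected: a 3.0-fold higher number from compound 3 to compound 4 (0.47 log units; beyond the scatter). The estimate for compound 4 is 250 nM, with an expected range of 80 nM to 750 nM.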

Compound 4, half-maximal inhibitory concentration: 123 nM
For compound 4 the middle estimate is 2.0-fold (0.31 log units) above the measured one; the measured number falls inside the stated range.
By their numbers in this assay, from the lowest: compounds 3, 4 and 1 (each within the scatter of the next); then compound 2.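

In this assay, a 4-substituted phenyl at this position is not in itself linked to a higher number: a 1.5-fold higher number from compound 3 to compound 4 (0.16 log units; within the scatter) and a 1.2-fold lower number from compound 1 to compound 4 (0.09 log units; within the scatter) leave 4-hydroxyphenyl unseparated from both pyridines. The higher number therefore tracks dimethylamino rather than the phenyl ring, with a 4.5-fold lower number from compound 2 to compound 4 (0.65 log units; beyond the scatter) on exchange for hydroxy. No available data explain the gap between these two groups. Going by these compounds, it remains open whether a primary amine or a carboxylic acid in place of that hydroxy would read like hydroxy or like dimethylamino.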